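The source may report more compounds than this note shows. Statements on the series, on what has been measured and on what is new or still open speak of the compounds shown alone.

Going by the values given here, compound 1 `CCn1cc(Nc2ncc3c(C)nn(-c4ccc(C#N)cc4)c3n2)cn1` is one of two compounds measured in an assay on isolated protein for inhibition of eIF-2-alpha kinase GCN2 (Homo sapiens) (on this read-out lower numbers stand for stronger inhibition and higher numbers for weaker inhibition), where compound 1 gives 56 nM. Compound 2 `COCCNC(=O)CNc1ncc2c(Br)nn(-c3ccc4ncccc4c3)c2n1` returns only a limit of the assay, > 1000 nM, so it stands at the limit of > 1000 nM in this assay, at which 1 of the 2 values shown sits. Compound 3 `CNC(=O)[C@@H]1CC[C@@H](Nc2ncc3c(Br)nn(-c4ccc5ncccc5c4)c3n2)C1` has not been measured; it differs from compound 2 in one place: a group of 9 heavy atoms (7 carbon, 1 nitrogen, 1 oxygen; one five-membered non-aromatic ring of carbon only) in place of a group of 8 heavy atoms (5 carbon, 1 nitrogen, 2 oxygen; no ring), on a nitrogen on an aromatic ring. Among the compounds with values here, no measured pair shows this kind of change, so the size of the step is uncertain; a gain of an at least 1.2-fold lower number from compound 2 to compound 3 (0.09 log units; that floor lies within the scatter) beyond the scatter is expected for compound 3. The estimate for compound 3 is 800 nM, between 150 nM and 4000 nM.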

Compound 3, half-maximal inhibitory concentration: 21 nM
Estimate against measurement, compound 3: 38-fold (1.58 log units) above, outside the stated range (below it).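

Placing the group with a five-membered non-aromatic ring of carbon only on the nitrogen on an aromatic ring, in place of ((2-methoxyethyl)carbamoyl)methyl, gives in this assay an at least 47-fold lower number from compound 2 to compound 3 (1.67 log units; beyond the scatter). This first readable step shows that the read-out responds strongly to the group at this place, even though both groups keep one double bond outside aromatic rings and one hydrogen-bond donor. Compound 2 stands at a limit of the assay and not at a number, so the step gives only a floor: the limit of > 1000 nM in this assay, at which 1 of the 3 values shown sits.

The compounds shown leave open whether the ring or the amide carries the gain, as a plain cyclopentyl group or a cyclopentyl group bearing a carboxylic acid would tell. They also leave open whether the two defined stereocentres matter.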